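The source may hold more compounds than are shown below. What is called first, only, known or untested is meant among the compounds shown, and "the series" means these compounds.

In a functional assay on the whole organism for inhibition, with Rattus norvegicus as the target, with a stated time of 4 h, at a dose of 33 mg/kg by the oral route (on this read-out lower numbers stand for less inhibition and higher numbers for more inhibition at the one dose given (going by the name of the read-out)), three compounds have been measured. Compound 1 `CN1C(C(=O)O)=C(O)c2ccccc2S1(=O)=O` gives 0%. Compound 3 `CN1C(=O)c2ccccc2S1(=O)=O` gives 12%. Within the data shown here, compound 2 `CN1C(C(=O)Nc2ccc(O)cn2)=C(O)c2ccccc2S1(=O)=O` gives 17%, the highest of the three numbers as they stand; its step from compound 1 is the one measured step, a number 17 percentage points higher from compound 1 to compound 2 (beyond the scatter), while its gap to compound 3 lies within the scatter, so no order between compound 2 and compound 3 can be read from these two numbers.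

Compound 4 `CN1C(C(=O)Nc2cccc(O)n2)=C(O)c2ccccc2S1(=O)=O` has not yet been measured in this assay. It differs from compound 2 only in how the same atoms are joined: 6-hydroxypyridin-2-yl in place of 5-hydroxypyridin-2-yl on an amide-type nitrogen. Among the measured compounds shown here, no measured step shifts a hydroxyl within the group that leaves or enters; the single measured step, a number 17 percentage points higher from compound 1 to compound 2 (beyond the scatter), concerns the amide as a whole against the carboxylic acid and gives no guide to this change. The expectation is therefore a step in this assay of no size beyond the scatter, a number 2 percentage points lower from compound 2 to compound 4 (within the scatter). Compound 4 is estimated at 15%, with a range from 0% to 35%.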

Compound 4, a percentage reported as inhibition, in the whole organism at one dose (the size of the read-out at that dose, not a potency): 40%
Compound 4: middle estimate off by 25 percentage points, on the low side; the measured number lies above the stated range.
By their numbers in this assay, from the lowest: compound 1; then compounds 3 and 2 (each within the scatter of the next); then compound 4.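

In this assay, 6-hydroxypyridin-2-yl in place of 5-hydroxypyridin-2-yl on the amide-type nitrogen, with the same atoms joined differently, gives a number 23 percentage points higher from compound 2 to compound 4 (beyond the scatter). The read-out therefore depends on how the hydroxyl is joined within this group and not only on the amide standing in place of the carboxylic acid: the step of a number 17 percentage points higher from compound 1 to compound 2 (beyond the scatter) becomes, with the other isomer, a number 40 percentage points higher from compound 1 to compound 4 (beyond the scatter). Nothing on hand explains this difference between the two groups.

It remains open whether the gain depends on the hydroxyl itself, since compounds with a methoxy group or an amine in its place on the 6-hydroxypyridin-2-yl group are not among those shown. With one dose and one time point, these numbers also leave the dose response of compound 4 open.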